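Cytotoxicity Limits Across a Shared Core Series

The compounds below may be only part of what the source reports. "The series", "measured", "known", "first", "only" and "open" are said of these compounds alone.

Measured so far:
compound 1 `COc1ccc(-c2ccc3ncc(-c4noc(C)n4)cc3c2)cc1`, > 66700 nM
compound 2 `CCCCc1ccc(-c2ccc3ncc(-c4noc(CC)n4)cc3c2)cc1`, > 7400 nM
compound 3 `CCc1ccc(-c2ccc3ncc(-c4noc(CC)n4)cc3c2)cc1`, > 22200 nM

In a functional assay on RD cells (Homo sapiens) for inhibition, read by luminescence and ATP content, with a stated time of 72 h (a lower number here means that less compound is tolerated, a higher number that more compound is tolerated), compound 3 gives only a limit, > 22200 nM. Every value in this assay is a limit: compound 1 is also reported only as a limit, > 66700 nM, and compound 2 likewise only as a limit, > 7400 nM. Among the compounds with values here, the one comparable step, a step that the two limits leave unreadable from compound 2 to compound 3, cannot be read in size because of the limit of > 7400 nM in this assay, at which 1 of the 3 values shown sits, and (the limit of > 22200 nM in this assay, at which 1 of the 3 values shown sits).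

Compound 4 `CCc1nc(-c2cnc3ccc(-c4ccc(OC)cc4)cc3c2)no1` differs from compound 3 by methoxy in place of ethyl on an aromatic carbon. Compound 1 also carries the methoxy group and is reported only at the limit of > 66700 nM in this assay, at which 1 of the 3 values shown sits. Within the data shown here, no measured step gives a readable size, so no change beyond a limit is expected; compound 4 is estimated at 50000 nM (range 15000 nM to 200000 nM), an expected step that the limit leaves unreadable from compound 3 to compound 4.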

Compound 4, half-maximal cytotoxic concentration: > 2500 nM
Compound 4 was reported as a limit; the forecaster's own chance of this, stated with the estimate: 85%; the middle value does not contradict the limit.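

In this assay compound 4 gives only a limit, > 2500 nM. The steps to compound 4 from compound 1, compound 2 and compound 3 cannot be read in size. The compounds shown leave open where any of their half-maximal cytotoxic concentrations actually lies.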